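The source may hold more compounds than are shown below. What is called first, only, known or untested is meant among the compounds shown, and "the series" means these compounds.

Measured so far in an in vitro assay on HEK-tsA201 cells for antagonist activity at Neuronal acetylcholine receptor; alpha3/beta4 (Homo sapiens), read by fluorescence and calcium flux; on this read-out lower numbers stand for stronger inhibition and higher numbers for weaker inhibition:
compound 1, `CCOc1ccc(C(=O)Nc2cc(C)cc(C)n2)cc1`: 17400 nM
compound 2, `C=CCOc1ccc(C(=O)Nc2cccc(Br)n2)cc1`: 65500 nM
compound 3, `CCCOc1ccc(C(=O)Nc2cccc(Br)n2)cc1`: only a limit of the assay, > 100000 nM

Compound 3 thus stands at the weak end of the three numbers shown, and it is the one compound whose result is a limit rather than a number, (the limit of > 100000 nM in this assay, at which 1 of the 3 values shown sits). Within the data shown here, its only neighbour by a single change is compound 2; that step is an at least 1.5-fold higher number from compound 2 to compound 3 (0.18 log units; that floor lies within the scatter), so the two cannot be told apart with confidence.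

Compound 4, `CCCCCNc1cccc(NC(=O)c2ccc(OCCC)cc2)n1`, is reached from compound 3 by pentylamino in place of bromo on an aromatic carbon. Among the measured compounds shown here, no measured pair changes this position: the one step on record, from compound 2 to compound 3, concerns the chain on the aromatic oxygen and was an at least 1.5-fold higher number from compound 2 to compound 3 (0.18 log units; that floor lies within the scatter). There is therefore no measured ground for a step in this assay in either direction, and the starting point itself is a limit, so the expected step from compound 3 to compound 4 is put at none beyond the scatter, an at least 1.2-fold lower number from compound 3 to compound 4 (0.09 log units; that floor lies within the scatter), with wide uncertainty. For compound 4 the estimate in this assay is 80000 nM, between 20000 nM and 300000 nM, and another limit remains a real possibility.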

Compound 4, half-maximal inhibitory concentration: > 100000 nM
Compound 4 was reported as a limit; the forecaster's own chance of this, stated with the estimate: 50%; middle value at least 1.2-fold (0.09 log units) from the limit.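

Compound 3 and compound 4 are both reported only as limits in this assay, so no step between them can be read: the limit of > 100000 nM in this assay, at which 2 of the 4 values shown sit.

The compounds shown leave open whether pentylamino in place of bromo on this aromatic carbon changes inhibition at all, and in which direction.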